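The source may report more compounds than this note shows. Statements on the series, on what has been measured and on what is new or still open speak of the compounds shown alone.

In a functional assay on A-375 cells (Homo sapiens) for antiproliferative activity, read by CCK-8 assay, with a stated time of 72 h, tested at 8 uM (a lower number here means a weaker effect, a higher number a stronger effect of the compound at the concentration tested), compound 1 `Nc1ccccc1NC(=O)c1ccc(CSC(=S)N2CCN(Cc3ccccn3)CC2)cc1` gives 82.4%, the higher of the two numbers recorded so far. In this assay compound 2 `Nc1ccccc1NC(=O)c1ccc(CSC(=S)N2CCc3ccc([N+](=O)[O-])cc32)cc1` gives 42%, a number far enough below compound 1 to lie beyond the usual scatter; the two structures differ in more than one place, so only their values can be set side by side. Compound 3 `COc1ccc(N2CCN(C(=S)SCc3ccc(C(=O)Nc4ccccc4N)cc3)CC2)cc1` is not yet measured. It differs from compound 1 by 4-methoxyphenyl in place of (pyridin-2-yl)methyl on an amine nitrogen in a ring. Going by the values given here, no measured pair shows this exchange. Compound 3 is expected to show a step of a number 10.4 percentage points lower from compound 1 to compound 3 (beyond the scatter), a small fall within or near the scatter. Compound 3 is estimated at 72%, with a range from 48% to 90%.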

Compound 3, a percentage reported as inhibition, at one concentration (the size of the read-out at that concentration, not a potency): 35.9%
Compound 3: middle estimate off by 36.1 percentage points, on the high side; the measured number lies below the stated range.
By their numbers in this assay, from the lowest: compounds 3 and 2 (each within the scatter of the next); then compound 1.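

Going by these compounds alone, on the amine nitrogen in the six-membered ring, the exchange of (pyridin-2-yl)methyl for 4-methoxyphenyl gives the first single change that can be read in this assay: a step of a number 46.5 percentage points lower from compound 1 to compound 3 (beyond the scatter). The position is therefore sensitive to the group it carries, even though both groups hold one six-membered aromatic ring and one hydrogen-bond acceptor and have no net charge. Nothing measured here explains the size of this step.

The compounds shown leave open which part of either group carries the step. A benzyl or an unsubstituted phenyl on the same nitrogen would speak to that.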